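Solubility of compound 3 from one measured step

The source may report more compounds than this note shows. Statements on the series, on what has been measured and on what is new or still open speak of the compounds shown alone.

Measured so far:
compound 1 `COc1cccc(CNCCCNc2ccnc3cc(Cc4ccccc4)ccc23)c1O` – 4200 nM
compound 2 `COc1cccc(CNCCCNc2ccnc3cc(-c4ccccc4)ccc23)c1O` – 32000 nM

In a physicochemical assay for solubility, with a stated time of 18 h, at pH 7.4 (on this read-out higher numbers stand for higher solubility and lower numbers for lower solubility), compound 2 gives 32000 nM, the higher of the two numbers recorded; its nearest neighbour is compound 1, and the step of a 7.6-fold higher number from compound 1 to compound 2 (0.88 log units; beyond the scatter) lies beyond the scatter. Compound 3 `COc1cccc(CNCCCNc2ccnc3cc(Oc4cccc(N(C)C)c4)ccc23)c1O` is the next compound to be measured. It differs from compound 2 in one place: 3-(dimethylamino)phenoxy in place of phenyl on an aromatic carbon. Within the data shown here, the only measured step concerns benzyl against phenyl, which is a different kind of change from the one leading to compound 3, so it gives no direct guide to size or direction here. With nothing bearing on this change, the expectation for compound 3 is a number near that of compound 2, with the step of a 1.3-fold lower number from compound 2 to compound 3 (0.11 log units; within the scatter) expected to stay within the scatter. Compound 3 is therefore estimated at 25000 nM, with a likely range from 8000 nM to 80000 nM.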

Compound 3, solubility: 14500 nM
Compound 3: the middle estimate sits 1.7-fold (0.24 log units) above what was measured, and the stated range covers the measured number.
By their numbers in this assay, from the lowest: compound 1; then compound 3; then compound 2.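

At this aromatic carbon of the shared core, this assay shifts when 3-(dimethylamino)phenoxy replaces phenyl, giving a 2.2-fold lower number from compound 2 to compound 3 (0.34 log units; beyond the scatter), and it shifts the other way when the same group replaces benzyl, giving a 3.5-fold higher number from compound 1 to compound 3 (0.54 log units; beyond the scatter). The new group is therefore placed between the other two, so among these three compounds the number does not simply fall as the group grows: compound 1, with benzyl rather than the larger new group, has the lowest number. No supporting measurement accounts for these differences.

The compounds shown leave open which part of the new group, the oxygen link or the dimethylamino group, goes with these steps. A plain phenoxy group or a carboxylic acid at this same carbon would help to separate those parts and test how far the trend extends.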